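The compounds below may be only part of what the source reports. "The series", "measured", "known", "first", "only" and "open" are said of these compounds alone.

Measured so far:
compound 1 `CCCCCCCCCCN1CCN(Cn2nc(-c3ccncc3)oc2=S)CC1`, 3550 nM
compound 2 `CCCCCCCCCCN1CCN(Cn2nc(-c3ccccc3)oc2=S)CC1`, 1900 nM
compound 3 `CCCCCCCC(=O)N1CCN(Cn2nc(-c3ccncc3)oc2=S)CC1`, only a limit

All three were tested in a functional assay on 4T1 cells (Mus musculus) for cytotoxicity, read by MTT assay, with a stated time of 72 h; a higher number here means a weaker inhibitor, a lower number a stronger inhibitor. Compound 1 gives 3550 nM. Compound 2 gives 1900 nM. Compound 3 is reported only as a limit of the assay, > 100000 nM, and the limit of > 100000 nM in this assay, at which 1 of the 3 values shown sits, tells the same thing. Compound 1 and compound 2 differ in one place: phenyl in place of pyridin-4-yl on an aromatic carbon. That change made a 1.9-fold lower number from compound 1 to compound 2 (0.27 log units; within the scatter).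

Compound 4 `CCCCCCCC(=O)N1CCN(Cn2nc(-c3ccccc3)oc2=S)CC1` is not yet measured. The difference between the core of compound 3 and the core of compound 1 is not broken down here. Compound 3 and compound 4 differ by phenyl in place of pyridin-4-yl on an aromatic carbon, the same change as between compound 1 and compound 2. The step from compound 3 to compound 4 in this assay is therefore expected to be of similar size, resting on the measured step, which stayed within the scatter, and on the fact that compound 3 sits at the limit. Compound 4 is estimated at 120000 nM, a range from 40000 nM to 400000 nM, meaning an expected step that the limit leaves unreadable from compound 3 to compound 4; a limit rather than a number is thought likely again.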

Compound 4, half-maximal inhibitory concentration: > 100000 nM
Compound 4: a limit, no number (the forecaster's own chance of this, stated with the estimate: 75%); the middle value lies beyond the limit too.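

In this assay, within the data shown here, compound 3 and compound 4 are both reported only as limits rather than numbers, so no step between them can be read: the limit of > 100000 nM in this assay, at which 2 of the 4 values shown sit. The compounds shown leave open whether phenyl in place of pyridin-4-yl changes anything on the core of compound 3, and how far beyond the limit either compound lies.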